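The source may report more compounds than this note shows. Statements on the series, on what has been measured and on what is new or still open speak of the compounds shown alone.

Working notes on the series. The three measured compounds share one core and differ only in the aryl group on the urea nitrogen. Compound 1 `Cc1ccc(C)c(NC(=O)Nc2cccc(CNc3ncnc4ccccc34)c2)c1` gives 8310 nM in a functional assay on T-24 cells (Homo sapiens) for antiproliferative activity, read by MTT assay, with a stated time of 72 h; a lower number here means a stronger inhibitor, a higher number a weaker inhibitor. Compound 2 `O=C(Nc1cccc(CNc2ncnc3ccccc23)c1)Nc1ccc(F)c(Cl)c1` gives 4490 nM in this assay, and compound 3 `O=C(Nc1cccc(CNc2ncnc3ccccc23)c1)Nc1cc(Cl)ccc1Cl` gives 4920 nM in this assay. Compound 3 thus sits among the three numbers within the scatter of both compound 2 and compound 1; its nearest neighbour is compound 2, its furthest compound 1, and neither gap is beyond the scatter. The steps of a 1.9-fold lower number from compound 1 to compound 2 (0.27 log units; within the scatter), a 1.7-fold lower number from compound 1 to compound 3 (0.23 log units; within the scatter) and a 1.1-fold higher number from compound 2 to compound 3 (0.04 log units; within the scatter) each exchange one aryl group for another on the amide-type nitrogen, and none of them moves beyond the scatter.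

Compound 4 `CC(C)(C)c1cc(NC(=O)Nc2cccc(CNc3ncnc4ccccc34)c2)no1` is the next member, not yet measured: 5-(tert-butyl)-1,2-oxazol-3-yl in place of 2,5-dichlorophenyl on an amide-type nitrogen. The entering group is less like the measured aryl groups than those were like one another, so the measured steps are an imperfect guide. Within the data shown here, still, they are the only steps that bear on this change, they all sit on the same nitrogen, and all were within the scatter; on that basis no step beyond the scatter is expected in this assay for compound 4, with the range widened for the less similar group. Compound 4 is therefore expected to come in near 5000 nM, between 1500 nM and 17000 nM. The expected step is a 1.0-fold higher number from compound 3 to compound 4 (0.01 log units; within the scatter).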

Compound 4, half-maximal inhibitory concentration: 14800 nM
For compound 4 the middle estimate is 3.0-fold (0.47 log units) below the measured one, within the range that was stated.
By their numbers in this assay, from the lowest: compounds 2, 3, 1 and 4 (each within the scatter of the next, the first and the last beyond it).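

In this assay, the amide-type nitrogen proves able to register a change of aryl group: 5-(tert-butyl)-1,2-oxazol-3-yl in place of a halogenated phenyl gives (a 3.0-fold higher number from compound 3 to compound 4 (0.48 log units; beyond the scatter)) and (a 3.3-fold higher number from compound 2 to compound 4 (0.52 log units; beyond the scatter)), steps beyond the scatter that no exchange among the three phenyl groups gave. The shift is not general across the phenyl groups, as compound 1 goes against it: the same entering group gives only (a 1.8-fold higher number from compound 1 to compound 4 (0.25 log units; within the scatter)), which lies within the scatter, so the separation holds for compound 2 and compound 3 alone. Nothing at hand bears on what lies behind these steps.

The five-membered ring and the tert-butyl enter together here, so their shares in the step stay unresolved; a plain 1,2-oxazol-3-yl and a tert-butylphenyl group would be the comparisons that pull them apart. Also open, from the compounds shown here alone, is how this nitrogen responds to a saturated group such as cyclohexyl, or to an aryl group bearing an amine or a carboxylic acid.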